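The source may report more compounds than this note shows. Statements on the series, on what has been measured and on what is new or still open speak of the compounds shown alone.

Measured compounds in an ADME assay on the whole organism with Oryza sativa as the target, tested at 0.1 uM; a lower number here means a stronger effect, a higher number a weaker effect of the compound at the concentration tested:
Compound 1, `CCCCCCCc1ccc(NC(=O)N[C@@H](C)c2ccccc2)cc1`, gives 100%.
Compound 2, `C[C@H](NC(=O)Nc1ccc(C(F)(F)F)cc1)c1ccccc1`, gives 94%.

Within the data shown here, compound 2 holds the lower of the two numbers measured so far, but its only neighbour is compound 1, and the single step between them, a number 6 percentage points lower from compound 1 to compound 2 (within the scatter), lies within the scatter, so the two readings cannot really be told apart. Compound 3, `C[C@H](NC(=O)Nc1ccc(Br)cc1)c1ccccc1`, has not yet been measured. It differs from compound 2 in one place: bromo in place of trifluoromethyl on an aromatic carbon. Among the measured compounds shown here, the one measured step, a number 6 percentage points lower from compound 1 to compound 2 (within the scatter), also swapped the group at this same aromatic carbon and did not move the reading beyond the scatter. For the measured compounds named here, no measured step shows what bromo does at this spot, so there is nothing in hand to suggest a shift in either direction. The expectation for compound 3 is therefore a reading close to that of compound 2, with the change no change at the digits printed from compound 2 to compound 3 (within the scatter) expected to stay within the scatter. Compound 3 is estimated to give 94%, with a likely range from 82% to 100%.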

Compound 3, a percentage reported as activity, at one concentration (the size of the read-out at that concentration, not a potency): 98%
The estimate for compound 3 lay 4 percentage points below the measured number; low and high end bracket the measured number.
By their numbers in this assay, from the lowest: compounds 2, 3 and 1 (each within the scatter of the next).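

In this assay, the aromatic carbon para to a large group now carries a third kind of group, bromo, a single heavy atom in place of the 4 heavy atoms of trifluoromethyl, and this step reads a number 4 percentage points higher from compound 2 to compound 3 (within the scatter). Set against heptyl at the same carbon, the step reads a number 2 percentage points lower from compound 1 to compound 3 (within the scatter), so with these three groups, the readings at this position cannot be told apart, despite the clear differences in the groups' size and make-up. No supporting information is available to explain why the readings stay together here.

Going by these compounds, what remains open is whether a group of a different kind at this carbon, such as an amine or a carboxylic acid, would move the reading in this assay beyond the scatter. On these data alone, it is equally open whether any change elsewhere on the shared core, such as replacing its methyl with a longer chain, would have a larger effect than these swaps at the aromatic carbon.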